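Furyl series: from methoxy to benzyloxy

The compounds below may be only part of what the source reports. "The series", "measured", "known", "first", "only" and "open" are said of these compounds alone.

Values in a functional assay on Vero cells (Chlorocebus sabaeus) for inhibition; a higher number here means a weaker inhibitor, a lower number a stronger inhibitor:
- compound 1 `Clc1cccc(Cn2cnc3c(-c4ccco4)ncnc32)c1` gives > 10 ug/mL
- compound 2 `Fc1ccc(Cn2cnc3c(-c4ccco4)ncnc32)cc1` gives > 10 ug/mL
- compound 3 `COc1ccc(Cn2cnc3c(-c4ccco4)ncnc32)cc1` gives > 62.5 ug/mL

All three values are limits, not numbers.

Compound 3 stands at a limit of > 62.5 ug/mL in this assay. Compound 4 `c1ccc(COc2ccc(Cn3cnc4c(-c5ccco5)ncnc43)cc2)cc1` has phenyl in place of hydrogen on a saturated chain carbon bound to an oxygen on an aromatic ring, turning methoxy to benzyloxy.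

Among the measured compounds shown here, two measured steps bear on this change: a step that the two limits leave unreadable from compound 2 to compound 3 and a step that the two limits leave unreadable from compound 1 to compound 2. Neither has a readable size, so neither supports a step beyond the scatter in either direction, and a further limit is the likely outcome.

The estimated step is an at least 1.0-fold lower number from compound 3 to compound 4 (0.01 log units; that floor lies within the scatter). For compound 4 the expected value is 60 ug/mL, with an estimated range of 15 ug/mL to 150 ug/mL.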

Compound 4, half-maximal inhibitory concentration: 1.7 ug/mL
The estimate for compound 4 lay 35-fold (1.55 log units) above the measured number; the measured number lies below the stated range.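

In this assay compound 4 is the only compound shown with a number rather than a limit, so this saturated chain carbon bound to an oxygen on an aromatic ring is a position where the read-out responds. Phenyl in place of hydrogen there gives an at least 36-fold lower number from compound 3 to compound 4 (1.56 log units; beyond the scatter), and benzyloxy in place of fluoro gives an at least 5.8-fold lower number from compound 2 to compound 4 (0.76 log units; beyond the scatter). Both sizes are floors and the earlier steps cannot be read, because the partner compounds stand at limits: the limit of > 10 ug/mL in this assay, at which 2 of the 4 values shown sit.

From the compounds shown here alone, whether phenethyloxy, a longer chain, or a carboxylic acid in place of the phenyl keeps this gain stays open. A single number sets no trend across the series.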